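Adding a Methyl to a Cathepsin S Inhibitor Side Chain

The compounds below may be only part of what the source reports. "The series", "measured", "known", "first", "only" and "open" are said of these compounds alone.

Compound 1, `CC(C)C[C@@H](NC(=O)N1CCOCC1)C(=O)N[C@H](C#N)CCc1ccccc1`: 11000 nM
Compound 2, `CC(C)C[C@](C)(NC(=O)N1CCOCC1)C(=O)N[C@H](C#N)CCc1ccccc1`: 76000 nM
Compound 3, `Cc1ccccc1COC[C@@H](C#N)NC(=O)[C@H](CC(C)C)NC(=O)N1CCOCC1`: 19 nM

In an assay for inhibition of cathepsin S (Homo sapiens) (on this read-out lower numbers stand for stronger inhibition and higher numbers for weaker inhibition), compound 1 gives 11000 nM. Compound 2 carries methyl in place of hydrogen on a saturated chain carbon bound to an amide-type nitrogen, a carbonyl carbon and a saturated chain carbon and gives 76000 nM, a step of a 6.9-fold higher number from compound 1 to compound 2 (0.84 log units; beyond the scatter). Compound 3 gives 19 nM, the lowest number of the three; how its core differs from the core of compound 1 is not broken down here.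

Compound 4, `Cc1ccccc1COC[C@@H](C#N)NC(=O)[C@H](CC(C)(C)C)NC(=O)N1CCOCC1`, is not yet measured. It differs from compound 3 by methyl in place of hydrogen on a saturated chain carbon bound to three saturated chain carbons. This is the same kind of change as that from compound 1 to compound 2, but not the same: there the carbon was bound to an amide-type nitrogen, a carbonyl carbon and a saturated chain carbon, here to three saturated chain carbons. Because the earlier step of a 6.9-fold higher number from compound 1 to compound 2 (0.84 log units; beyond the scatter) sat at a different place, it is only a loose guide, and a smaller step is expected here, about a 1.6-fold higher number from compound 3 to compound 4 (0.20 log units; within the scatter). Compound 4 is therefore estimated at about 30 nM, between 8 nM and 120 nM.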

Compound 4, half-maximal inhibitory concentration: 12 nM
The estimate for compound 4 lay 2.5-fold (0.40 log units) above the measured number, and the stated range covers the measured number.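

Turning isobutyl into neopentyl in this assay brings a 1.6-fold lower number from compound 3 to compound 4 (0.20 log units; within the scatter) and so makes no clear difference on this core. Methyl in place of hydrogen therefore does not carry a fixed effect from one core to the other: the same change on two cores in this assay, a 6.9-fold higher number (0.84 log units; beyond the scatter) from compound 1 to compound 2 and a 1.6-fold lower number (0.20 log units; within the scatter) from compound 3 to compound 4, 11-fold (1.04 log units) apart, beyond the scatter of two such steps

This does not show that the core alone sets the size of the step, as the methyl also sits on a different carbon in each pair, and each place is seen only once.

The compounds shown leave open what a methyl on the carbon bound to an amide-type nitrogen, a carbonyl carbon and a saturated chain carbon would do on the core of compound 3. They also leave open how a longer chain or an amine at the tert-butyl site would read.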